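This account rests on a few compounds, and the source may have more. Where it says the series, first, only, none or still open, it means among the compounds named here.

Measured in an ADME assay on HFF cells (Homo sapiens) for cytotoxicity, with a stated time of 8 days; on this read-out higher numbers stand for lower toxicity in this test and lower numbers for higher toxicity in this test:

Compound 1 `Nc1nc(OCc2ccccc2)c2ncn(/C=C3/CC3(CO)CO)c2n1`: > 300000 nM, a limit
Compound 2 `CC(C)Nc1nc(N)nc2c1ncn2/C=C1/CC1(CO)CO`: > 300000 nM, a limit
Compound 3 `CCCCCOc1nc(N)nc2c1ncn2/C=C1/CC1(CO)CO`: 259000 nM

Compound 3 alone carries an actual number, 259000 nM. Compound 1 and compound 2 both rest on (the limit of > 300000 nM in this assay, at which 2 of the 3 values shown sit).

Compound 4 `CCCCOc1nc(N)nc2c1ncn2/C=C1/CC1(CO)CO` differs from compound 3 by one change: hydrogen in place of methyl on a saturated chain carbon, four bonds along the chain from an oxygen on an aromatic ring. In words, hydrogen takes the place of methyl on a saturated chain carbon, four bonds along the chain from an oxygen on an aromatic ring.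

For the measured compounds named here, no measured step isolates this change. Two steps arrive at compound 3. One is an at least 1.1-fold lower number from compound 1 to compound 3 (0.06 log units; that floor lies within the scatter), with butyl in place of phenyl. The other is an at least 1.1-fold lower number from compound 2 to compound 3 (0.06 log units; that floor lies within the scatter), with pentyloxy in place of isopropylamino. The remaining step, a step that the two limits leave unreadable from compound 1 to compound 2, gives no size. Both readable steps exchange more of the structure than the loss of one methyl, and neither has a floor beyond the scatter in this assay. On that basis, no step beyond the scatter is expected here, in either direction. The expected step is a 1.1-fold higher number from compound 3 to compound 4 (0.03 log units; within the scatter). The assay may also report only a limit. Compound 4 is estimated at 280000 nM, with an expected range from 170000 nM to 450000 nM.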

Compound 4, half-maximal cytotoxic concentration: > 300000 nM
Compound 4 gave a limit, no number; the forecaster's own chance of this, stated with the estimate: 50%; at least 1.0-fold (0.02 log units) between middle value and limit.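

Hydrogen in place of methyl, four bonds along the chain from an oxygen on an aromatic ring, is now read directly for the first time in this assay: the change gives an at least 1.1-fold higher number from compound 3 to compound 4 (0.06 log units; that floor lies within the scatter), which is a floor and not a measured size. Compound 4 rests on a limit, so compound 3 remains the only compound shown with an actual number, and this change, like the two earlier readable steps, shows nothing beyond the scatter. The steps from compound 1 and from compound 2 to compound 4 join two limits and cannot be read, and most of the comparison now rests on a single limit: the limit of > 300000 nM in this assay, at which 3 of the 4 values shown sit.

Going by these compounds, how large the step from pentyloxy to butoxy really is stays open beyond that floor. On these data alone, whether a longer chain such as hexyloxy, or an amine such as butylamino in place of butoxy, would give an actual number in this assay also stays open.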